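Aryl replacement on the shared core: compound 3 to compound 4

The compounds below may be only part of what the source reports. "The series", "measured", "known", "first", "only" and "open" are said of these compounds alone.

Measured so far in a functional assay on SW-620 cells (Homo sapiens) for antiproliferative activity, read by MTT assay, with a stated time of 72 h; a lower number here means a stronger inhibitor, a higher number a weaker inhibitor:
compound 1 `CC(C)(C)c1cn(C[C@H](O)[C@H]2OC(=O)C(OCc3ccccc3)=C2OCc2ccccc2)nn1` — compound 1 gives 35800 nM
compound 2 `Cc1ccc(S(=O)(=O)NCc2cn(C[C@H](O)[C@H]3OC(=O)C(OCc4ccccc4)=C3OCc3ccccc3)nn2)cc1` — compound 2 gives 45800 nM
compound 3 `COc1ccccc1-c1cn(C[C@H](O)[C@H]2OC(=O)C(OCc3ccccc3)=C2OCc2ccccc2)nn1` — compound 3 reaches only the limit of the assay, > 100000 nM, so no number is known for it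

Among the three measured compounds, compound 3 stands weakest: the steps of an at least 2.7-fold higher number from compound 1 to compound 3 (0.44 log units; beyond the scatter) and an at least 2.1-fold higher number from compound 2 to compound 3 (0.33 log units; beyond the scatter) are both beyond the scatter, whereas a 1.3-fold higher number from compound 1 to compound 2 (0.11 log units; within the scatter) is within it. All three measured values lie in the weak region of this assay, and one of them sits at the limit of > 100000 nM in this assay, at which 1 of the 3 values shown sits.

Compound 4 `CCCCCc1ccc(-c2cn(C[C@H](O)[C@H]3OC(=O)C(OCc4ccccc4)=C3OCc3ccccc3)nn2)cc1` differs from compound 3 in one place: 4-pentylphenyl in place of 2-methoxyphenyl on an aromatic carbon. Within the data shown here, no measured step exchanges one aryl group for another on this carbon. The nearest evidence is the two steps that end in compound 3, both from a smaller group to 2-methoxyphenyl, and both went toward weaker inhibition. Whether 4-pentylphenyl behaves like 2-methoxyphenyl or like the smaller groups cannot be told from these three compounds alone.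

Compound 4 is therefore expected to remain a weak inhibitor, with an estimated 80000 nM and a range from 30000 nM to 200000 nM. The expected step is an at least 1.2-fold lower number from compound 3 to compound 4 (0.09 log units; that floor lies within the scatter), with a real chance that compound 4 is also reported only as a limit.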

Compound 4, half-maximal inhibitory concentration: 12200 nM
Compound 4: middle estimate off by 6.6-fold (0.82 log units), on the high side; the whole stated range lies above it.
By their numbers in this assay, from the lowest: compound 4; then compounds 1 and 2 (each within the scatter of the next). At a limit, above all of these: compound 3.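

In this assay, among these compounds, 2-methoxyphenyl was the only aryl group on this aromatic carbon of the five-membered ring until now, and it gave the weakest reading, but 4-pentylphenyl shows that an aryl group here does not in itself weaken the compound, giving an at least 8.1-fold lower number from compound 3 to compound 4 (0.91 log units; beyond the scatter). Compound 4 also stands clear of both compounds with non-aryl groups on this carbon, with a 3.8-fold lower number from compound 2 to compound 4 (0.57 log units; beyond the scatter) and a 2.9-fold lower number from compound 1 to compound 4 (0.47 log units; beyond the scatter), so among these four compounds the outcome depends on which aryl group is present, not simply on whether one is present. The value of compound 3 is a limit and not a number, so the exchange of aryl groups has a floor but no known size: the limit of > 100000 nM in this assay, at which 1 of the 4 values shown sits.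

The two aryl groups differ both in their substituent and in its place on the ring, so the compounds shown do not separate these two changes; 4-methoxyphenyl or unsubstituted phenyl would bear on that. From the compounds shown here alone, whether the gain tracks the pentyl chain also stays open, and 4-methylphenyl, 4-octylphenyl or a chain ending in an amine or a carboxylic acid would test it.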